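Swapping an iodo group for a hydroxyl: cytotoxicity outlook

The compounds below may be only part of what the source reports. "The series", "measured", "known", "first", "only" and "open" are said of these compounds alone.

In an ADME assay on Huh-7 cells (Homo sapiens) for cytotoxicity (on this read-out higher numbers stand for lower toxicity in this test and lower numbers for higher toxicity in this test), compound 2 `O=c1cc(CNCc2ccccc2I)oc2ccc(O)c(O)c12` gives 87300 nM. Of the two plain numbers shown, this is the higher, yet the step of a 1.7-fold lower number from compound 2 to compound 3 (0.22 log units; within the scatter) is within the scatter, compound 3 being `Cc1ccccc1CNCc1cc(=O)c2c(O)c(O)ccc2o1` with 52200 nM. Compound 1 `O=c1cc(CNCc2ccccc2Cl)oc2ccc(O)c(O)c12` reaches only a limit of this assay, > 100000 nM (the limit of > 100000 nM in this assay, at which 1 of the 3 values shown sits). The steps of an at least 1.1-fold lower number from compound 1 to compound 2 (0.05 log units; that floor lies within the scatter) and an at least 1.9-fold lower number from compound 1 to compound 3 (0.28 log units; that floor lies within the scatter) rest on that limit. Compound 4 `O=c1cc(CNCc2cccc(O)c2)oc2ccc(O)c(O)c12` is not yet measured; it differs from compound 2 by 3-hydroxyphenyl in place of 2-iodophenyl on a saturated chain carbon bound to an amine nitrogen. Within the data shown here, no measured step exchanges a 2-iodophenyl for a 3-hydroxyphenyl, and every step seen stays within the scatter, so for compound 4 no move beyond the scatter is expected, a 1.0-fold higher number from compound 2 to compound 4 (0.01 log units; within the scatter). Compound 4 is therefore estimated at 90000 nM, between 40000 nM and 200000 nM.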

Compound 4, half-maximal cytotoxic concentration: > 100000 nM
Compound 4: only a limit was reported; the forecaster's own chance of this, stated with the estimate: 40%; at least 1.1-fold (0.04 log units) between middle value and limit.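

Unlike the chloro, iodo and methyl rings before it, the 3-hydroxyphenyl of compound 4 brings a hydrogen-bond donor, and compound 4 gives a limit rather than a number in this assay: the limit of > 100000 nM in this assay, at which 2 of the 4 values shown sit.

The readable steps are an at least 1.1-fold higher number from compound 2 to compound 4 (0.05 log units; that floor lies within the scatter) and an at least 1.9-fold higher number from compound 3 to compound 4 (0.28 log units; that floor lies within the scatter), so this change shows no real shift. The step between the two compounds at the limit cannot be read.

As far as these compounds go, what 2-hydroxyphenyl would give stays open, so the hydroxyl cannot be separated from its place on the ring. A ring carrying a carboxylic acid is also unexplored here.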